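The compounds below may be only part of what the source reports. "The series", "measured", "known", "first", "only" and "open" are said of these compounds alone.

Going by the values given here, compound 1 `C=C1[C@@H](OC(C)=O)C[C@@H]2[C@](C)(COC=O)[C@H](OC(C)=O)CC[C@@]2(C)[C@@H]1C[C@@H](Nc1ccccc1C(=O)O)C1=CCOC1=O` is the weakest of the three compounds measured so far in a functional assay on KB cells (Homo sapiens) for cytotoxicity, read by sulforhodamine B assay; a higher number here means a weaker inhibitor, a lower number a stronger inhibitor: in that test compound 1 gives 42500 nM. Its two companions differ from it in two places at once, at the core and on the amine nitrogen. Compound 2 `C=C1[C@@H](OC(C)=O)C[C@@H]2[C@](C)(CO[Si](C)(C)C(C)(C)C)[C@H](OC(C)=O)CC[C@@]2(C)[C@@H]1C[C@@H](Nc1ccc(C(=O)O)cc1)C1=CCOC1=O` gives 5540 nM, and compound 3 `C=C1[C@@H](OC(C)=O)C[C@@H]2[C@](C)(CO[Si](C)(C)C(C)(C)C)[C@H](OC(C)=O)CC[C@@]2(C)[C@@H]1C[C@@H](Nc1cccc2ccccc12)C1=CCOC1=O` gives 8930 nM, so compound 1 stands well apart from both, and the gap to each of them is larger than the scatter of repeated measurements.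

The step to the unmeasured compound 4 `C=C1[C@@H](OC(C)=O)C[C@@H]2[C@](C)(COC=O)[C@H](OC(C)=O)CC[C@@]2(C)[C@@H]1C[C@@H](Nc1ccccc1)C1=CCOC1=O` changes only the group on the amine nitrogen: hydrogen in place of carboxy on an aromatic carbon, that is, 2-carboxyphenyl becomes phenyl. Among the compounds with values here, the one measured step that also alters the aromatic group on the nitrogen, a 1.6-fold higher number from compound 2 to compound 3 (0.21 log units; within the scatter), exchanged 4-carboxyphenyl for naphthalen-1-yl without moving the number beyond the scatter. Within the data shown here, no measured pair isolates the removal of a carboxy group, and no measured pair shares the core of compound 1 and compound 4. The little that bears on the question therefore points to a small step in this assay, with no clear direction. Compound 4 is expected to give 30000 nM, within a range of 8000 nM to 110000 nM. This estimate means an expected 1.4-fold lower number from compound 1 to compound 4 (0.15 log units; within the scatter), which stays within the scatter.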

Compound 4, half-maximal inhibitory concentration: 32100 nM
Beside the measured number, compound 4's estimate is 1.1-fold (0.03 log units) below it; the measured number falls inside the stated range.
By their numbers in this assay, from the lowest: compounds 2 and 3 (each within the scatter of the next); then compounds 4 and 1 (each within the scatter of the next).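

Going by these compounds alone, compound 1 and compound 4 form the first pair here that differs only by the carboxy group, so this is the first direct look at that group on the shared core. In this assay, replacing it with a hydrogen atom gives a 1.3-fold lower number from compound 1 to compound 4 (0.12 log units; within the scatter), so on this core the number does not depend measurably on whether the aromatic carbon ortho to a large group carries carboxy or hydrogen. The earlier compounds could not show this, since none of them isolates the loss of a carboxy group, and no available evidence explains the result.

As far as these compounds go, it remains open whether a different group at this same place, such as an amine, a hydroxyl or a methoxy group, would move the number beyond the scatter, or whether a carboxy group would matter if it sat elsewhere on the phenyl ring of this core. From the compounds shown here alone, it is also open whether removing the carboxy group from the 4-carboxyphenyl of compound 2 would be just as small a step on the core that carries the tert-butyldimethylsilyl ether.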